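Leaving 3-Bromophenyl: An Expected Small Step

This account rests on a few compounds, and the source may have more. Where it says the series, first, only, none or still open, it means among the compounds named here.

Compound 1 `COc1cc(/C=C(\C#N)C(=O)N/N=C(\C)c2c(O)c3ccc(O)cc3oc2=O)ccc1O` gives 10500 nM
Compound 2 `C/C(=N\NC(=O)/C(C#N)=C/c1ccccc1[N+](=O)[O-])c1c(O)c2ccc(O)cc2oc1=O` gives 10300 nM
Compound 3 `C/C(=N\NC(=O)/C(C#N)=C/c1cccc(Br)c1)c1c(O)c2ccc(O)cc2oc1=O` gives 24300 nM

In a functional assay on HeLa cells (Homo sapiens) for cytotoxicity, read by MTT assay, with a stated time of 24 h (on this read-out higher numbers stand for weaker inhibition and lower numbers for stronger inhibition), compound 3 stands highest of the three at 24300 nM and is the weakest here, while the other two lie within the scatter of each other: a 1.0-fold lower number from compound 1 to compound 2 (0.01 log units; within the scatter). Compound 4 `C/C(=N\NC(=O)/C(C#N)=C/c1ccccc1Cl)c1c(O)c2ccc(O)cc2oc1=O` has 2-chlorophenyl in place of 3-bromophenyl on a double-bonded chain carbon bound to a double-bonded chain carbon. Among the compounds with values here, two measured steps bear on this, a 2.3-fold higher number from compound 1 to compound 3 (0.36 log units; beyond the scatter) and a 2.4-fold higher number from compound 2 to compound 3 (0.37 log units; beyond the scatter), both modest and each bringing in 3-bromophenyl. With that group leaving, a small move to a lower number in this assay is expected, not clearly beyond the scatter: a 1.6-fold lower number from compound 3 to compound 4 (0.21 log units; within the scatter). For compound 4 the estimated value is 15000 nM, with an expected range from 8000 nM to 28000 nM.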

Compound 4, half-maximal inhibitory concentration: 11800 nM
The estimate for compound 4 lay 1.3-fold (0.10 log units) above the measured number, within the range that was stated.
By their numbers in this assay, from the lowest: compounds 2, 1 and 4 (each within the scatter of the next); then compound 3.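

In this assay, 2-chlorophenyl in place of 3-bromophenyl at this place gives a step beyond the scatter, though a modest one (a 2.1-fold lower number from compound 3 to compound 4 (0.31 log units; beyond the scatter)). Chloro in place of nitro on an aromatic carbon (a 1.1-fold higher number from compound 2 to compound 4 (0.06 log units; within the scatter)) and 2-chlorophenyl in place of 4-hydroxy-3-methoxyphenyl (a 1.1-fold higher number from compound 1 to compound 4 (0.05 log units; within the scatter)) both stay within the scatter, so of these four compounds only compound 3 stands apart. Nothing measured here accounts for this.

Open, going by these compounds, is whether 3-bromophenyl stands apart for its bromine or for where that bromine sits, which a 3-chlorophenyl would separate. On these data alone, how a 4-aminophenyl or a 3-carboxyphenyl group would read at this place also remains open.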